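A few compounds are considered here, and "the series" means these few. Any claim that something is new, unique, unknown or untested is made for them only; others in the source may bear on it.

In a functional assay on RPMI-8226 cells (Homo sapiens) for cytotoxicity, read by MTT assay, with a stated time of 48 h (on this read-out lower numbers stand for stronger inhibition and higher numbers for weaker inhibition), compound 1 `O=C(c1ccccc1)N(N=C1C(Cl)=C(Cl)C(Cl)=C1Cl)C(=O)c1ccccc1` gives 800 nM. Compound 2 `C#CC(C)(C)OC(=O)NN=C1C(Cl)=C(Cl)C(Cl)=C1Cl` is reported only as a limit, > 5000 nM, so it has no exact value on this read-out. Compound 3 `CC(C)(C)OC(=O)NN=C1C(Cl)=C(Cl)C(Cl)=C1Cl` has methyl in place of ethynyl on a saturated chain carbon bound to an oxygen next to a carbonyl group and two saturated chain carbons. Going by the values given here, no measured pair of compounds tests this change, and the expected step in this assay, a step that the limit leaves unreadable from compound 2 to compound 3, is none beyond the scatter. The estimate for compound 3 is 6000 nM, with an expected range of 2000 nM to 15000 nM.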

Compound 3, half-maximal inhibitory concentration: 100 nM
Compound 3: middle estimate off by 60-fold (1.78 log units), on the high side; the whole stated range lies above it.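

In this assay, the change of ethynyl to methyl on a saturated chain carbon bound to an oxygen next to a carbonyl group and two saturated chain carbons gives an at least 50-fold lower number from compound 2 to compound 3 (1.69 log units; beyond the scatter), so this place is far from indifferent to the group it carries. Compound 2 is reported only as a limit: the limit of > 5000 nM in this assay, at which 1 of the 3 values shown sits.

The true size of the step therefore stays unread. It also stays open whether tert-butoxy is specially favoured or ethynyl alone is poorly tolerated, since no other group, such as an ethyl, a longer chain or an amine, stands at this place among the compounds shown.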